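A few compounds are considered here, and "the series" means these few. Any claim that something is new, unique, unknown or untested is made for them only; others in the source may bear on it.

The study measures an ADME assay on CCRF-HSB-2 cells (Homo sapiens) for cytotoxicity, with a stated time of 7 days; a higher number here means that more compound is tolerated, a lower number that less compound is tolerated. Compound 1, `CCCCCCCCOc1nc(N)nc2c1ncn2/C=C1/CC1(CO)CO`, gives in this assay > 20000 nM, which is a limit of the assay rather than a number. Compound 2, `Nc1nc(NC2CCCC2)c2ncn(/C=C3/CC3(CO)CO)c2n1`, likewise gives in this assay > 20000 nM, again a limit. Compound 3, `COCCOc1nc(N)nc2c1ncn2/C=C1/CC1(CO)CO`, also reaches only a limit in this assay, > 20000 nM. All three values therefore sit at the limit of > 20000 nM in this assay, at which 3 of the 3 values shown sit, and none of the steps between them can be read: a step that the two limits leave unreadable from compound 1 to compound 2, a step that the two limits leave unreadable from compound 1 to compound 3 and a step that the two limits leave unreadable from compound 2 to compound 3. Compound 4, `CCCCCCOc1nc(N)nc2c1ncn2/C=C1/CC1(CO)CO`, has not yet been measured. It differs from compound 3 by butyl in place of methoxy on a saturated chain carbon, two bonds along the chain from an oxygen on an aromatic ring. This change lies between compound 3 and compound 1, both of which give only a limit, so nothing in the measured steps points to a step beyond the scatter in this assay. The expected step is a step that the limit leaves unreadable from compound 3 to compound 4. Compound 4 is expected to give 30000 nM in this assay, within the range 10000 nM to 100000 nM, and most likely to be reported again only as a limit.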

Compound 4, half-maximal cytotoxic concentration: > 20000 nM
Compound 4 ended at the assay's limit; the forecaster's own chance of this, stated with the estimate: 80%; the middle value lies beyond the limit too.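

Compound 4 adds no readable step to compound 1, compound 2 or compound 3 in this assay, since each value is only a limit of the assay: the limit of > 20000 nM in this assay, at which 4 of the 4 values shown sit. The compounds shown leave open at what concentration any of them becomes cytotoxic, and whether they differ at all.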